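Growing the acyl group on a sugar ester, one carbon more

The source may report more compounds than this note shows. Statements on the series, on what has been measured and on what is new or still open speak of the compounds shown alone.

Two sugar-derived esters have been tested so far in a functional assay on NCI-H460 cells (Homo sapiens) for antiproliferative activity, read by MTT assay, with a stated time of 48 h; on this read-out lower numbers stand for stronger inhibition and higher numbers for weaker inhibition. Compound 1 `CCCCCCCCO[C@@H]1O[C@@H](C)[C@H](OC(=O)CCCCC)[C@@H](O[C@@H]2O[C@@H](C)[C@H](OC(C)=O)[C@@H](OC(C)=O)[C@H]2OC(C)=O)[C@H]1O` gives 15000 nM. Compound 2 `CCCCCCCCO[C@@H]1O[C@@H](C)[C@H](OC(=O)CCCCC)[C@@H](O[C@@H]2O[C@@H](C)[C@H](OC(C)=O)[C@@H](OC(=O)C(C)C)[C@H]2OC(C)=O)[C@H]1O` gives 47000 nM, the higher of the two numbers. Going by the values given here, the one measured step, a 3.1-fold higher number from compound 1 to compound 2 (0.50 log units; beyond the scatter), came from putting isopropyl in place of methyl on a carbonyl carbon.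

Compound 3 `CCCCCCCCO[C@@H]1O[C@@H](C)[C@H](OC(=O)CCCCC)[C@@H](O[C@@H]2O[C@@H](C)[C@H](OC(C)=O)[C@@H](OC(=O)C(C)(C)C)[C@H]2OC(C)=O)[C@H]1O` carries the same change one step further: methyl in place of hydrogen on a saturated chain carbon bound to a carbonyl carbon and two saturated chain carbons. Among the compounds with values here, the only step that speaks to it is a 3.1-fold higher number from compound 1 to compound 2 (0.50 log units; beyond the scatter), which moved the number upward beyond the scatter when the group on that carbonyl carbon grew. On that basis a further upward step is expected from compound 2 to compound 3, about a 2.1-fold higher number from compound 2 to compound 3 (0.33 log units; beyond the scatter), though a single step is a thin basis. Compound 3 is therefore expected to give roughly 100000 nM in this assay, within a range from 40000 nM to 250000 nM.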

Compound 3, half-maximal inhibitory concentration: 141000 nM
Beside the measured number, compound 3's estimate is 1.4-fold (0.15 log units) below it, within the range that was stated.
By their numbers in this assay, from the lowest: compound 1; then compound 2; then compound 3.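

At this position the number did not level off after the first enlargement: one more methyl, turning isopropyl into tert-butyl, gave a 3.0-fold higher number from compound 2 to compound 3 (0.48 log units; beyond the scatter) in this assay and so repeated the upward direction of the earlier step. Taken end to end, tert-butyl in place of methyl on the carbonyl carbon amounts to a 9.4-fold higher number from compound 1 to compound 3 (0.97 log units; beyond the scatter) and places the three compounds in one order, with weaker inhibition as the group grows and no compound going against it. Nothing measured here explains this rise.

Going by these compounds, all three groups are branched or small, so it remains open whether a longer unbranched chain such as hexyl, or a phenyl ring, on this carbonyl carbon would follow the same order. On these data alone, the effect of the same change on the other acetyl groups of the shared core is also open.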